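The source may report more compounds than this note shows. Statements on the series, on what has been measured and on what is new or still open speak of the compounds shown alone.

Compound 1 `COc1cc(-c2cc(COCc3cn(Cc4cc(-c5ccccc5)cnc4Cl)nn3)on2)cc(OC)c1OC`: 68500 nM
Compound 2 `COc1cc(C2CC(COCc3cn(Cc4cc(-c5ccc(F)cc5)cnc4Cl)nn3)ON2C=O)cc(OC)c1OC`: 45700 nM

In a functional assay on MCF7 cells (Homo sapiens) for cytotoxicity, read by MTT assay, with a stated time of 48 h (on this read-out lower numbers stand for stronger inhibition and higher numbers for weaker inhibition), compound 1 gives 68500 nM and compound 2 gives 45700 nM. These two numbers lie within the usual scatter of each other, so compound 1 cannot be ranked against compound 2.

Compound 3 `COc1cc(-c2cc(COCc3cn(Cc4cc(-c5ccc(F)cc5)cnc4Cl)nn3)on2)cc(OC)c1OC` keeps the core of compound 1 and has one change, fluoro in place of hydrogen on an aromatic carbon, turning phenyl to 4-fluorophenyl. Going by the values given here, no measured pair shows this change alone, so no step beyond the scatter is expected. The estimated step is a 1.2-fold lower number from compound 1 to compound 3 (0.10 log units; within the scatter). Compound 3 is expected at 55000 nM, with an estimated range of 25000 nM to 110000 nM.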

Compound 3, half-maximal inhibitory concentration: 76400 nM
Beside the measured number, compound 3's estimate is 1.4-fold (0.14 log units) below it; low and high end bracket the measured number.
By their numbers in this assay, from the lowest: compounds 2, 1 and 3 (each within the scatter of the next).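

In this assay, going by these compounds alone, putting fluoro in place of hydrogen on the phenyl ring gives a 1.1-fold higher number from compound 1 to compound 3 (0.05 log units; within the scatter) and is the first measured pair to isolate this change. At this place on the ring, para to a large group, hydrogen and fluoro therefore cannot be told apart on this read-out. Nothing measured here offers an explanation for this result. From the compounds shown here alone, whether an amine or a carboxylic acid at the same place would move the number beyond the scatter remains open.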